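The compounds below may be only part of what the source reports. "The series", "measured", "known", "first", "only" and "open" are said of these compounds alone.

The measured compounds and their values in a physicochemical assay for solubility, read by HPLC, with a stated time of 24 h; a higher number here means a more soluble compound, a lower number a less soluble compound:
compound 1, `CCN1CCN(C[C@H]2CN(c3ccc(-n4cc(-c5ccccn5)cn4)c(F)c3)C(=O)O2)CC1`, gives 706000 nM;
compound 2, `O=C1O[C@@H](CN2CCC(O)CC2)CN1c1ccc(-n2cc(-c3ccccn3)cn2)c(F)c1`, gives 45900 nM;
compound 3, `O=C1CCC(=O)N1C[C@H]1CN(c2ccc(-n3cc(-c4ccccn4)cn3)c(F)c2)C(=O)O1`, gives 45300 nM.

Compound 2 stands second highest of the three numbers. Its nearest neighbour is compound 3, whose value lies within the scatter of it (a 1.0-fold lower number from compound 2 to compound 3 (0.01 log units; within the scatter)), while compound 1 stands far above it (a 15-fold lower number from compound 1 to compound 2 (1.19 log units; beyond the scatter)). The unmeasured compound 4 has the structure `O=CNC[C@H]1CN(c2ccc(-n3cc(-c4ccccn4)cn3)c(F)c2)C(=O)O1`. The change from compound 2 to compound 4 is formylamino in place of 4-hydroxypiperidin-1-yl on a saturated chain carbon bound to a saturated ring carbon.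

Within the data shown here, two measured steps bear on this change. Both a 15-fold lower number from compound 1 to compound 2 (1.19 log units; beyond the scatter) and a 16-fold lower number from compound 1 to compound 3 (1.19 log units; beyond the scatter) are large and run downward, and both replace 4-ethylpiperazin-1-yl at this place. The step of a 1.0-fold lower number from compound 2 to compound 3 (0.01 log units; within the scatter), which exchanges one ring for another at the same place, stays within the scatter. Among the measured compounds shown here, no measured step replaces a ring there with a group without a ring, so the account rests on these three.

The analyst therefore expects for compound 4 a step within the scatter, a 1.1-fold lower number from compound 2 to compound 4 (0.06 log units; within the scatter). Compound 4 is estimated at 40000 nM, with a range from 12000 nM to 130000 nM.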

Compound 4, solubility: 217000 nM
Compound 4: middle estimate off by 5.4-fold (0.73 log units), on the low side, outside the stated range (above it).
By their numbers in this assay, from the lowest: compounds 3 and 2 (each within the scatter of the next); then compound 4; then compound 1.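

In this assay, among these compounds, the earlier compounds left 4-hydroxypiperidin-1-yl and 2,5-dioxopyrrolidin-1-yl within the scatter of each other on a saturated chain carbon bound to a saturated ring carbon, whereas formylamino, which has no ring, stands apart from both (a 4.7-fold higher number from compound 2 to compound 4 (0.67 log units; beyond the scatter)) and (a 4.8-fold higher number from compound 3 to compound 4 (0.68 log units; beyond the scatter)). It still does not reach the 4-ethylpiperazin-1-yl group (a 3.3-fold lower number from compound 1 to compound 4 (0.51 log units; beyond the scatter)), so among these four compounds this place gives three separate levels, and a group without a ring sits in the middle one. Nothing measured here accounts for the difference.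

The compounds shown do not separate the absence of a ring from the lower heavy-atom count or from the formyl carbonyl, as these change together in compound 4. An acetylamino group or a plain primary amine at this place would bear on that question.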